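This account rests on a few compounds, and the source may have more. Where it says the series, first, only, none or still open, it means among the compounds named here.

Measured so far in an assay on isolated protein for inhibition of Calpain-1 catalytic subunit (Sus scrofa), read by FRET; on this read-out lower numbers stand for stronger inhibition and higher numbers for weaker inhibition:
- compound 1 `O=C(O)/C(S)=C/c1c[nH]c2cc(Cl)ccc12`: 210 nM
- compound 2 `O=C(O)/C(S)=C/c1ccccc1I`: 29600 nM

Of the two numbers, compound 1 gives the lower one, 210 nM, and so stands as the stronger inhibitor; the gap to compound 2, which gives 29600 nM, is far beyond the usual scatter of this assay. The next compound, compound 3 `O=C(O)/C(S)=C/c1c[nH]c2cc(I)ccc12`, keeps the core of compound 1 and differs from it in a single place: iodo in place of chloro on an aromatic carbon. Within the data shown here, nothing measured so far tests this particular exchange on this core, so the step from compound 1 to compound 3 is expected to be small, a 1.1-fold higher number from compound 1 to compound 3 (0.04 log units; within the scatter), with no clear direction beyond the scatter. On that basis compound 3 is estimated to give about 230 nM in this assay, most likely between 80 nM and 700 nM.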

Compound 3, half-maximal inhibitory concentration: 170 nM
Compound 3: middle estimate off by 1.4-fold (0.13 log units), on the high side; low and high end bracket the measured number.
By their numbers in this assay, from the lowest: compounds 3 and 1 (each within the scatter of the next); then compound 2.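

In this assay, iodo in place of chloro on an aromatic carbon of the six-membered ring, meta to a fused ring and para to a fused ring, gives a 1.2-fold lower number from compound 1 to compound 3 (0.09 log units; within the scatter). Among these compounds, this is the first direct test of this position, and it shows that, on the core of compound 1, chloro and iodo cannot be told apart in this read-out. No independent measurement bears on why the two halogens give numbers within the scatter of each other.

The compounds shown carry only these two halogens at this place, so they leave open what an amine, a methoxy group or a plain hydrogen would give there. They also leave open whether the same exchange would read alike at the other carbons of that ring.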